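Chloro in place of trifluoromethyl: working notes

The source may report more compounds than this note shows. Statements on the series, on what has been measured and on what is new or still open speak of the compounds shown alone.

Measured in a functional assay on QGY-7703 cells (Homo sapiens) for cytotoxicity, read by MTT assay, with a stated time of 24 h; on this read-out lower numbers stand for stronger inhibition and higher numbers for weaker inhibition:
- compound 1 `CN1C/C(=C\c2ccncc2)C(=O)/C(=C/c2ccccc2F)C1`: 4900 nM
- compound 2 `O=C1/C(=C/c2cccnc2)CN(S(=O)(=O)c2ccc(Cl)cc2)C/C1=C\c1ccccc1F`: 12100 nM
- compound 3 `O=C1/C(=C/c2ccncc2)CN(S(=O)(=O)c2ccc(C(F)(F)F)cc2)C/C1=C\c1ccccc1F`: 9500 nM

At 9500 nM, compound 3 lies within the scatter of both compound 2 and compound 1. Compound 4 `O=C1/C(=C/c2ccncc2)CN(S(=O)(=O)c2ccc(Cl)cc2)C/C1=C\c1ccccc1F` has chloro in place of trifluoromethyl on an aromatic carbon, para to a large group (chloro in place of trifluoromethyl on an aromatic carbon). Going by the values given here, no measured pair isolates this change. Compound 2, which also carries 4-chlorophenyl, gives 12100 nM, so no shift beyond the scatter is expected in this assay. The expected outcome is a small step of a 1.1-fold higher number from compound 3 to compound 4 (0.02 log units; within the scatter). The estimate for compound 4 is 10000 nM, with an expected range of 6000 nM to 17000 nM.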

Compound 4, half-maximal inhibitory concentration: 12500 nM
Compound 4: the middle estimate sits 1.3-fold (0.10 log units) below what was measured, and the stated range covers the measured number.
By their numbers in this assay, from the lowest: compounds 1, 3, 2 and 4 (each within the scatter of the next, the first and the last beyond it).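

Chloro in place of trifluoromethyl now has a direct pair in this assay: the change gives a 1.3-fold higher number from compound 3 to compound 4 (0.12 log units; within the scatter) and leaves the number within the scatter. Pyridin-4-yl in place of pyridin-3-yl likewise gives a 1.0-fold higher number from compound 2 to compound 4 (0.01 log units; within the scatter) while (4-chlorophenyl)sulfonyl in place of methyl on the amine nitrogen in the ring gives a 2.6-fold higher number from compound 1 to compound 4 (0.41 log units; beyond the scatter) and is the only one of these steps beyond the scatter. No available evidence bears on the reason for these steps.

On these data alone, whether an amine or a carboxylic acid on this aromatic carbon would move the number beyond the scatter remains open.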